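Replacing a hydroxy group with nitro on a hydrazone

The source may report more compounds than this note shows. Statements on the series, on what has been measured and on what is new or still open speak of the compounds shown alone.

Measured compounds:
Compound 1, `O=C(COc1cccc2ccccc12)N/N=C/c1ccc(O)cc1`: 26.5 ug/mL
Compound 2, `O=C(COc1cccc2ccccc12)N/N=C/c1cccc(O)c1`: 32.6 ug/mL
Compound 3, `O=C(COc1cccc2ccccc12)N/N=C/C=C/c1ccccc1`: 82.7 ug/mL

All three compounds share a core and differ only in the group attached to the carbon that carries a double bond to nitrogen. In an ADME assay on MT4 cells (Homo sapiens) for cytotoxicity, read by MTT assay, with a stated time of 4 days (a lower number here means that less compound is tolerated, a higher number that more compound is tolerated), compound 1 gives 26.5 ug/mL, the lowest of the three numbers. Moving the hydroxy group gives a 1.2-fold higher number from compound 1 to compound 2 (0.09 log units; within the scatter), so compound 1 and compound 2 cannot be told apart. Exchanging the ring for a 2-phenylethenyl group gives a 3.1-fold higher number from compound 1 to compound 3 (0.49 log units; beyond the scatter), a modest rise.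

Compound 4, `O=C(COc1cccc2ccccc12)N/N=C/c1ccc([N+](=O)[O-])cc1`, has not yet been measured. It differs from compound 1 by nitro in place of hydroxy on an aromatic carbon, placed para to a large group. Among the compounds with values here, no measured step swaps one small substituent for another on the same ring, so the nearest guide is the small step from compound 1 to compound 2 and the modest one to compound 3. A change of this kind is therefore expected to stay near compound 1, with at most a small rise. The estimated step is a 1.3-fold higher number from compound 1 to compound 4 (0.12 log units; within the scatter), giving compound 4 an expected value of 35 ug/mL in this assay, within a range from 17 ug/mL to 75 ug/mL.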

Compound 4, half-maximal cytotoxic concentration: 87.9 ug/mL
The estimate for compound 4 lay 2.5-fold (0.40 log units) below the measured number; measured number outside the range, above it.
By their numbers in this assay, from the lowest: compounds 1 and 2 (each within the scatter of the next); then compounds 3 and 4 (each within the scatter of the next).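

In this assay, within the data shown here, nitro in place of hydroxy gives a 3.3-fold higher number from compound 1 to compound 4 (0.52 log units; beyond the scatter), whereas moving the hydroxy group, the only earlier change that kept the ring, gave a 1.2-fold higher number from compound 1 to compound 2 (0.09 log units; within the scatter), so the choice of substituent on this ring can matter even though moving the hydroxy group did not. With the ring kept and only this substituent exchanged, compound 4 falls within the scatter of compound 3, in which a 2-phenylethenyl group replaces the whole hydroxy-bearing ring. Nothing measured here says why the number rises.

From the compounds shown here alone, it remains open whether the rise depends on nitro itself or would also appear with an amine, a methoxy group or a chlorine atom at this place, para to a large group. A bare phenyl ring with no substituent would show whether losing hydroxy alone is enough to produce it.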